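One Ring Rearranged Between Two Measured Neighbours

A few compounds are considered here, and "the series" means these few. Any claim that something is new, unique, unknown or untested is made for them only; others in the source may bear on it.

In a functional assay on DU-145 cells (Homo sapiens) for inhibition, read by trypan blue exclusion, with a stated time of 96 h (a higher number here means a weaker inhibitor of growth, a lower number a stronger inhibitor of growth), compound 1 `O=C(/C(=C\c1ccc([N+](=O)[O-])c(O)c1)SCc1ccc(Br)cc1)c1ccc([N+](=O)[O-])c(Cl)c1` gives 1000 nM and compound 2 `O=C(O)c1ccc(C(=O)/C(=C\c2ccc(O)c([N+](=O)[O-])c2)SCc2ccc(Br)cc2)cc1` gives 50000 nM as its reading. Compound 2 therefore has the higher of the two numbers, which makes it the weaker inhibitor of growth, and the gap lies beyond the scatter. These two compounds differ in more than one place, so the data cannot tie that gap to any single group.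

Compound 3 `O=C(O)c1ccc(C(=O)/C(=C\c2ccc([N+](=O)[O-])c(O)c2)SCc2ccc(Br)cc2)cc1` has not yet been measured. It has the same atoms as compound 2, joined differently: 3-hydroxy-4-nitrophenyl stands in place of 4-hydroxy-3-nitrophenyl on a double-bonded chain carbon bound to a double-bonded chain carbon (3-hydroxy-4-nitrophenyl in place of 4-hydroxy-3-nitrophenyl on a double-bonded chain carbon bound to a double-bonded chain carbon).

Compound 1 also carries 3-hydroxy-4-nitrophenyl and gives 1000 nM in this assay so a move toward a lower number is expected, although a single compound is thin evidence. The expected change is a 6.3-fold lower number from compound 2 to compound 3 (0.80 log units; beyond the scatter) which would lie beyond the scatter. For compound 3 the estimated value is 8000 nM with an expected range from 1500 nM to 50000 nM in this measurement.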

Compound 3, concentration for 50% growth inhibition: 10000 nM
Compound 3: the middle estimate sits 1.3-fold (0.10 log units) below what was measured; the range from low to high includes it.
By their numbers in this assay, from the lowest: compound 1; then compound 3; then compound 2.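

The arrangement of the two groups on this ring matters in its own right: in this assay, 3-hydroxy-4-nitrophenyl in place of 4-hydroxy-3-nitrophenyl gives a 5.0-fold lower number from compound 2 to compound 3 (0.70 log units; beyond the scatter) while every atom count stays the same. The other end of the molecule also matters, as 4-carboxyphenyl in place of 3-chloro-4-nitrophenyl on a carbonyl carbon gives a 10-fold higher number from compound 1 to compound 3 (1.00 log units; beyond the scatter) and so accounts for the rest of the wide gap that could not be divided before, with each of the two changes beyond the scatter on its own. Nothing in the data on hand says why either change moves the number.

Going by these compounds, each change rests on a single pair, so it remains open whether the ring rearrangement would shift the number in the same way with 3-chloro-4-nitrophenyl on the carbonyl carbon instead of 4-carboxyphenyl. On these data alone, it is equally open how a methyl ester or an amide would read in place of the carboxylic acid, or a methoxy group in place of the hydroxy group on the rearranged ring.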